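The source may hold more compounds than are shown below. What is called first, only, known or untested is meant among the compounds shown, and "the series" means these compounds.

In a functional assay on BT-20 cells (Homo sapiens) for cytotoxicity, read by MTT assay, with a stated time of 68 h (a higher number here means a weaker inhibitor, a lower number a stronger inhibitor), compound 1 `O=C(/C=C/c1cccc(OCc2ccccc2)c1)c1ccc(Cl)cc1Cl` gives 19200 nM, the lowest of the two numbers at hand. Compound 2 `Cc1ccc(C(=O)/C=C/c2cccc(OCc3ccccc3)c2)cc1` gives 61000 nM, so the change from compound 1 to compound 2 is a 3.2-fold higher number from compound 1 to compound 2 (0.50 log units; beyond the scatter). Compound 3 `O=C(/C=C/c1cccc(OCc2ccccc2)c1)c1cccc(Br)c1` differs from compound 1 by 3-bromophenyl in place of 2,4-dichlorophenyl on a carbonyl carbon. Among the measured compounds shown here, the single measured step also replaces the aryl group on the carbonyl carbon and was modest, so a shift of comparable size, most likely upward, is the reasonable expectation here. Compound 3 is therefore expected to give 30000 nM (range 10000 nM to 90000 nM), an estimated step of a 1.6-fold higher number from compound 1 to compound 3 (0.19 log units; within the scatter).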

Compound 3, half-maximal inhibitory concentration: 7100 nM
The estimate for compound 3 lay 4.2-fold (0.63 log units) above the measured number; the measured number lies below the stated range.
By their numbers in this assay, from the lowest: compound 3; then compound 1; then compound 2.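

In this assay, changing the aryl group on the carbonyl carbon can lower the number as well as raise it: 3-bromophenyl gives a 2.7-fold lower number from compound 1 to compound 3 (0.43 log units; beyond the scatter) and an 8.6-fold lower number from compound 2 to compound 3 (0.93 log units; beyond the scatter). This place therefore spans a wider range than the earlier single rise showed, with compound 3 lowest of the three. Nothing given here explains this result. Going by these compounds, whether the lower number follows the bromine or the absence of the two chlorines stays open, since both differ at once. On these data alone, how an amine or a carboxylic acid on this aryl group would read also remains unknown.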